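A few compounds are considered here, and "the series" means these few. Any claim that something is new, unique, unknown or untested is made for them only; others in the source may bear on it.

Compound 1 `Oc1ccc(-c2nc3cc(C(F)(F)F)ccc3[nH]2)cc1` was tested in an ADME assay on BHK cells (Mesocricetus auratus) for cytotoxicity, read by MTT assay, with a stated time of 96 h; on this read-out higher numbers stand for lower toxicity in this test and lower numbers for higher toxicity in this test. In this assay compound 1 gives > 100000 nM, which is a limit of the assay rather than a number. Among the measured compounds shown here, this is the only limit among the values shown: the limit of > 100000 nM in this assay, at which 1 of the 2 values shown sits. The second measured compound, compound 2 `O=C(CN1CCCCC1)Nc1ccc(-c2nc3ccccc3[nH]2)cc1`, carries an amide in place of the hydroxy, and in this assay compound 2 gives 31000 nM, a number well inside the range of the assay. Compound 3 `O=C(CCl)Nc1ccc(-c2nc3cc(C(F)(F)F)ccc3[nH]2)cc1` has not yet been measured. It differs from compound 1 in one place: ((chloromethyl)carbonyl)amino in place of hydroxy on an aromatic carbon. For the measured compounds named here, no measured pair differs in only that place, so the size of the step is open. The value of compound 2 in this assay, 31000 nM, is the nearest guide. A step of an at least 5.0-fold lower number from compound 1 to compound 3 (0.69 log units; beyond the scatter) is expected, downward from the limit. Compound 3 is therefore expected to give about 20000 nM in this assay, within a range from 5000 nM to 80000 nM.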

Compound 3, half-maximal cytotoxic concentration: 22000 nM
Compound 3: the middle estimate sits 1.1-fold (0.04 log units) below what was measured; the measured number falls inside the stated range.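

With compound 3, the hydroxy position of compound 1 is shown for the first time to matter in this assay: ((chloromethyl)carbonyl)amino in place of hydroxy, on the aromatic carbon para to a large group, gives an at least 4.5-fold lower number from compound 1 to compound 3 (0.65 log units; beyond the scatter). The direction is toward higher toxicity in this test, and the step lies beyond the usual scatter, so this change at this one place is enough to bring a number inside the range of the assay. The size of the step remains only a lower bound, because one end of it is a limit of the assay and not a number: the limit of > 100000 nM in this assay, at which 1 of the 3 values shown sits.

The compounds shown leave open whether the chlorine or the amide accounts for the step. A plain acetylamino group, a free amine or a longer chain at this place would be needed to separate the two.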